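The source may hold more compounds than are shown below. What is called first, only, known or untested is meant among the compounds shown, and "the series" means these compounds.

Compound 1, `Oc1cccc(-c2cc(-c3ccoc3)cc(-c3ccccc3O)n2)c1` — > 50000 nM
Compound 2, `Oc1cccc(-c2cc(-c3ccccn3)cc(-c3ccccc3O)n2)c1` — 2020 nM

In a functional assay on HeLa cells (Homo sapiens) for cytotoxicity, read by CCK-8 assay (a higher number here means a weaker inhibitor, a lower number a stronger inhibitor), compound 1 reaches only a limit, > 50000 nM, as the limit of > 50000 nM in this assay, at which 1 of the 2 values shown sits, records. Compound 2 gives 2020 nM in this assay, the only result that is a number rather than a limit. Going by the values given here, the one measured step, an at least 24-fold lower number from compound 1 to compound 2 (1.39 log units; beyond the scatter), shows that the ring at this position matters greatly. Compound 3, `Oc1cccc(-c2cc(-c3cccnc3)cc(-c3ccccc3O)n2)c1`, differs from compound 2 by pyridin-3-yl in place of pyridin-2-yl on an aromatic carbon. Among the compounds with values here, no measured step compares the two pyridyl isomers, so the direction is uncertain; a modest loss is expected, a 1.7-fold higher number from compound 2 to compound 3 (0.24 log units; within the scatter). Compound 3 is estimated at 3500 nM, between 900 nM and 20000 nM.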

Compound 3, half-maximal inhibitory concentration: 7530 nM
Beside the measured number, compound 3's estimate is 2.2-fold (0.33 log units) below it; measured number inside the range.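

In this assay pyridin-3-yl in place of pyridin-2-yl gives a 3.7-fold higher number from compound 2 to compound 3 (0.57 log units; beyond the scatter) and so shows that the place of the ring nitrogen counts at this position, not just the presence of a pyridine ring. Pyridin-3-yl in place of furan-3-yl still gives an at least 6.6-fold lower number from compound 1 to compound 3 (0.82 log units; beyond the scatter) and so both pyridine isomers stand ahead of the furan-3-yl compound. That step is only a bound, since compound 1 stands at a limit: the limit of > 50000 nM in this assay, at which 1 of the 3 values shown sits.

The compounds shown leave open how pyridin-4-yl or a plain phenyl ring would compare at this position. They also leave open whether an amine on the ring would be tolerated.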